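A few compounds are considered here, and "the series" means these few. Any claim that something is new, unique, unknown or untested is made for them only; others in the source may bear on it.

The shared core of these compounds is seen in compound 2 `CCN(Cc1ccccn1)c1ccc(C(=O)N2CCc3ccc(OS(N)(=O)=O)cc3C2)cc1`, where an amide links a substituted aromatic ring to the sulfamate-bearing part. In an assay on HEK293 cells for inhibition of Steryl-sulfatase (Homo sapiens), tested at 1 uM (on this read-out higher numbers stand for a stronger effect at the one concentration tested and lower numbers for a weaker effect), compound 2 gives 87.7%, the highest of the three numbers measured. Compound 1 `CCN(Cc1ccccc1)c1cccc(C(=O)N2CCc3ccc(OS(N)(=O)=O)cc3C2)c1` gives 69% in this assay, and compound 3 `CN(C)CCN(CCN(C)C)c1cccc(C(=O)N2CCc3ccc(OS(N)(=O)=O)cc3C2)c1` gives 17.1%, the lowest of the three.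

Going by the values given here, only one step between two measured compounds differs in a single place: the change from benzyl(ethyl)amino to bis(2-(dimethylamino)ethyl)amino lowers inhibition sharply, a number 51.9 percentage points lower from compound 1 to compound 3 (beyond the scatter). Among the compounds with values here, compound 2 differs from compound 1 and compound 3 in more than one place, so no single-point step to it is known.

Compound 4 `CCCN(Cc1ccccc1)c1ccc(C(=O)N2CCc3ccc(OS(N)(=O)=O)cc3C2)cc1` is not yet measured. Its difference from compound 2 is benzyl(propyl)amino in place of ethyl((pyridin-2-yl)methyl)amino on an aromatic carbon. Within the data shown here, the one measured step does not concern this kind of change; it shows only that a benzyl group on the amino nitrogen, as in compound 1 with 69%, keeps inhibition high, and the pyridine-bearing compound 2 stands somewhat higher again. A modest step, a number 12.7 percentage points lower from compound 2 to compound 4 (beyond the scatter), is therefore expected, downward but not certainly beyond the scatter. Compound 4 is estimated at 75% in this assay, with a range from 55% to 90%.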

Compound 4, a percentage reported as inhibition, at one concentration (the size of the read-out at that concentration, not a potency): 94.3%
Beside the measured number, compound 4's estimate is 19.3 percentage points below it; measured number outside the range, above it.
By their numbers in this assay, from the lowest: compound 3; then compound 1; then compounds 2 and 4 (each within the scatter of the next).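

In this assay, benzyl(propyl)amino in place of ethyl((pyridin-2-yl)methyl)amino on this aromatic carbon, para to a large group, gives a number 6.6 percentage points higher from compound 2 to compound 4 (within the scatter), so this exchange leaves the read-out unchanged within the usual scatter. The pyridine ring nitrogen is therefore not needed for a high read-out at this position, since a six-membered aromatic ring of carbon only, carried with a propyl chain, serves as well at the one concentration tested. No measurement at hand explains why the two groups match.

The ring and the chain changed together, so the share of each in the result cannot be separated. On these data alone, whether a methyl or butyl chain on the nitrogen, or a carboxylic acid on the benzyl ring, would keep the read-out this high remains open.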